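Replacing Phenylsulfonyl with (3,4-Difluorophenyl)carbonyl at an Assay Limit

A few compounds are considered here, and "the series" means these few. Any claim that something is new, unique, unknown or untested is made for them only; others in the source may bear on it.

Values measured in an ADME assay on Karpas-1106P cells (Homo sapiens) for cytotoxicity (on this read-out lower numbers stand for an effect already at smaller amounts and higher numbers for an effect only at larger amounts of compound), each one a limit of the assay:
- compound 1 `Cc1ccc(S(=O)(=O)N[C@@H](CC(=O)NC(C)(C)C)C(=O)NCCNC(=O)c2cc(Cl)ccc2Cl)cc1`: > 11100 nM
- compound 2 `Cc1ccc(S(=O)(=O)N[C@@H](CC(=O)NC(C)(C)C)C(=O)NCCNC(=O)c2cc(C)ccc2F)cc1`: > 11100 nM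
- compound 3 `Cc1ccc(S(=O)(=O)N[C@@H](CC(=O)NC(C)(C)C)C(=O)NCCNS(=O)(=O)c2ccccc2)cc1`: > 11100 nM

Compound 3 stands at the limit of > 11100 nM in this assay, at which 3 of the 3 values shown sit. Compound 4 `Cc1ccc(S(=O)(=O)N[C@@H](CC(=O)NC(C)(C)C)C(=O)NCCNC(=O)c2ccc(F)c(F)c2)cc1` differs from it in one place, with (3,4-difluorophenyl)carbonyl in place of phenylsulfonyl on an amine nitrogen.

The closest measured changes at that nitrogen are a step that the two limits leave unreadable from compound 1 to compound 3 and a step that the two limits leave unreadable from compound 2 to compound 3. In each of them, a substituted phenylcarbonyl and phenylsulfonyl are exchanged. Neither has a size that can be read, and no direction can be taken from them. No step beyond the usual scatter is therefore expected in this assay. The estimated step is a step that the limit leaves unreadable from compound 3 to compound 4. Compound 4 is most likely expected to return only a limit again. As a number, compound 4 is estimated at 12000 nM, with an expected range from 5000 nM to 30000 nM.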

Compound 4, half-maximal effective concentration: > 11100 nM
Compound 4 gave a limit, no number; the forecaster's own chance of this, stated with the estimate: 85%; the middle value does not contradict the limit.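

Compound 4 returned > 11100 nM, a limit of the assay and not a number. Its steps to compound 1, compound 2 and compound 3 cannot be read, and all four compounds sit at the same limit: the limit of > 11100 nM in this assay, at which 4 of the 4 values shown sit.

The compounds shown leave open at what concentration any of them would show an effect in this assay, and whether any of these exchanges alters that concentration.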